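The compounds below may be only part of what the source reports. "The series", "measured", "known", "first", "only" and "open" are said of these compounds alone.

Measured compounds:
compound 1 `CC(=O)c1ccc(-c2cn3ccnc3c(-c3ccc4ncn(C5CCCCC5)c4c3)n2)cc1` — 18.8%
compound 2 `Clc1ccc(-c2cn3ccnc3c(-c3ccc4ncn(C5CCCCC5)c4c3)n2)cc1` — 15.5%

Both compounds were read in a functional assay on HCT-15 cells (Homo sapiens) for inhibition, read by sulforhodamine B assay, with a stated time of 48 h, tested at 10 uM; on this read-out higher numbers stand for more inhibition at the one concentration tested (going by the name of the read-out) and lower numbers for less inhibition. Compound 2 sits at the lower end of the two numbers, separated from compound 1 by a number 3.3 percentage points lower from compound 1 to compound 2 (within the scatter), a gap within the scatter, so the two are not distinguished on this read-out.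

Compound 3 `Brc1ccc(-c2cn3ccnc3c(-c3ccc4ncn(C5CCCCC5)c4c3)n2)cc1` is not yet measured. It differs from compound 2 by bromo in place of chloro on an aromatic carbon. For the measured compounds named here, the only measured step, acetyl to chloro, concerns a different group at the same place and was itself within the scatter; no step between halogens has been measured. On that basis no change beyond the scatter is expected from compound 2 to compound 3, and the estimated step is a number 0.5 percentage points higher from compound 2 to compound 3 (within the scatter). Compound 3 is therefore expected to give about 16% in this assay, with a range from 6% to 28%.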

Compound 3, a percentage reported as inhibition, at one concentration (the size of the read-out at that concentration, not a potency): 35.8%
For compound 3 the middle estimate is 19.8 percentage points below the measured one, outside the stated range (above it).
By their numbers in this assay, from the lowest: compounds 2 and 1 (each within the scatter of the next); then compound 3.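

In this assay this place on the aromatic ring, para to a large group, proves sensitive to the exchange of one halogen for another: a number 20.3 percentage points higher from compound 2 to compound 3 (beyond the scatter) even though acetyl and chloro could not be told apart there. Bromo also stands clear of acetyl with a number 17 percentage points higher from compound 1 to compound 3 (beyond the scatter) so among the three groups shown at this place, only bromo separates from the other two. No data at hand account for the difference between the 4-chlorophenyl and 4-bromophenyl compounds.

Open, going by these compounds, is whether iodo would carry the trend beyond bromo, or whether an amine or a carboxylic acid at this place would match bromo. Also open, on these data alone, is how these compounds would compare at other concentrations, since each has a reading at a single one.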